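Removing a Chlorine from a Quinone Cytotoxin

The source may report more compounds than this note shows. Statements on the series, on what has been measured and on what is new or still open speak of the compounds shown alone.

Measured compounds:
compound 1, `Cc1cc(Cl)c2c(c1O)C(=O)C=CC2=O`, 9400 nM
compound 2, `CCOc1cc(C)cc2c1C(=O)C=CC2=O`, 25300 nM
compound 3, `CCOc1cc(C)c(Cl)c2c1C(=O)C=CC2=O`, 44200 nM

All three were tested in a functional assay on SNO cells (Homo sapiens) for cytotoxicity, read by XTT assay, with a stated time of 24 h; on this read-out lower numbers stand for stronger inhibition and higher numbers for weaker inhibition. Compound 1 gives the lowest of the three numbers; compound 2 comes nearest to it and compound 3 lies furthest away. Compound 2 and compound 3 share a core, and the step between them is a 1.7-fold lower number from compound 3 to compound 2 (0.24 log units; within the scatter), a change described as hydrogen in place of chloro on an aromatic carbon. The difference between the core of compound 1 and the core of compound 3 is not broken down here.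

Compound 4, `Cc1ccc2c(c1O)C(=O)C=CC2=O`, has not yet been measured in this assay. It arises from compound 1 by the same kind of change, (hydrogen in place of chloro on an aromatic carbon); the surroundings differ in that here the carbon is meta to a methyl group and para to a hydroxy group, whereas in the earlier pair it was ortho to a methyl group and para to an ethoxy group. Because the earlier step was a 1.7-fold lower number from compound 3 to compound 2 (0.24 log units; within the scatter), the step expected for compound 4 is a 1.3-fold lower number from compound 1 to compound 4 (0.10 log units; within the scatter). The estimated value for compound 4 is therefore 7500 nM, with a range from 3000 nM to 20000 nM.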

Compound 4, half-maximal inhibitory concentration: 19000 nM
The estimate for compound 4 lay 2.5-fold (0.40 log units) below the measured number, within the range that was stated.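

In this assay, putting hydrogen in place of chloro on the core of compound 1 gives a 2.0-fold higher number from compound 1 to compound 4 (0.31 log units; beyond the scatter), a modest step. Set beside the earlier step, this shows that the same change does not carry over unaltered from one core to the other in this series: the same change on two cores in this assay, a 1.7-fold lower number (0.24 log units; within the scatter) from compound 3 to compound 2 and a 2.0-fold higher number (0.31 log units; beyond the scatter) from compound 1 to compound 4, 3.5-fold (0.55 log units) apart, beyond the scatter of two such steps

Among the compounds shown here, with only two pairs, this does not show what in the cores sets the two steps apart, nor how the change would behave on a further core; on the core of compound 1, the carbon that carries the change is meta to a methyl group and para to a hydroxy group, but these surroundings have not been tested one at a time here.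

The compounds shown leave open whether the hydroxy group or the ethoxy group goes with the different outcomes, as no pair here differs in that group alone. They also leave open how the core of compound 1 would respond if an amine or a carboxylic acid stood where the chloro sits.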